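The source may hold more compounds than are shown below. What is called first, only, known or untested is meant among the compounds shown, and "the series" means these compounds.

Measured compounds in a functional assay on HeLa cells (Homo sapiens) for inhibition, read by MTT assay, with a stated time of 72 h; on this read-out higher numbers stand for weaker inhibition and lower numbers for stronger inhibition:
Compound 1 `CC(C)c1cc(C(C)C)c(C(=O)/C=C/C(=O)O)c(C(C)C)c1` gives 6100 nM.
Compound 2 `CC(C)(C)c1ccc(C(=O)/C=C/C(=O)O)cc1` gives 5100 nM.
Compound 3 `CCc1ccc(C(=O)/C=C/C(=O)O)cc1` gives 27800 nM.

Compound 3 stands at the highest of the three numbers. Its nearest neighbour is compound 1, and compound 2 lies furthest from it; both of these gaps are beyond the scatter, so compound 3 is the weakest inhibitor of the three that have been measured.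

Compound 4 `O=C(O)/C=C/C(=O)c1ccc(Br)cc1` has not yet been measured. It differs from compound 3 in one place: bromo in place of ethyl on an aromatic carbon. For the measured compounds named here, the single measured step that touches this position is a 5.5-fold higher number from compound 2 to compound 3 (0.74 log units; beyond the scatter), which shows that the group at this place, para to a group of 7 heavy atoms, can move the number by a modest amount, with tert-butyl giving the lower value. Going by the values given here, no measured compound carries bromo, or any halogen, at this position, so the direction of the present change cannot be read from the data. With nothing to anchor the direction, the step is expected to stay within the scatter, a 1.9-fold lower number from compound 3 to compound 4 (0.27 log units; within the scatter). For compound 4 the estimate in this assay is 15000 nM, with a range from 5000 nM to 45000 nM.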

Compound 4, half-maximal inhibitory concentration: 18700 nM
Estimate against measurement, compound 4: 1.2-fold (0.10 log units) below; measured number inside the range.
By their numbers in this assay, from the lowest: compounds 2 and 1 (each within the scatter of the next); then compounds 4 and 3 (each within the scatter of the next).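

In this assay, bromo in place of ethyl on an aromatic carbon, para to a group of 7 heavy atoms, gives a 1.5-fold lower number from compound 3 to compound 4 (0.17 log units; within the scatter), so this first halogen at the position cannot be told apart from ethyl. Bromo in place of tert-butyl at the same place gives a 3.7-fold higher number from compound 2 to compound 4 (0.56 log units; beyond the scatter), which together with a 5.5-fold higher number from compound 2 to compound 3 (0.74 log units; beyond the scatter) sets tert-butyl apart from both ethyl and bromo, the position's earlier single step now being matched by a second one beyond the scatter. Among these three groups, then, tert-butyl alone stands clear of the others, while the difference between ethyl and bromo is lost in the scatter, and nothing available accounts for either result.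

As far as these compounds go, whether fluoro or chloro at this place would fall with bromo, and whether a methoxy group or an amine would fall with ethyl or with tert-butyl, remains open. Also open, from the compounds shown here alone, is whether a longer chain such as n-butyl would reach the level of tert-butyl, or whether a branched group such as isopropyl is needed at this position.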